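A few compounds are considered here, and "the series" means these few. Any claim that something is new, unique, unknown or untested is made for them only; others in the source may bear on it.

Of the compounds shown here, two of this study have been measured in an assay on isolated protein for inhibition of leukotriene B4 receptor 1 (Homo sapiens), tested at 10 uM; a lower number here means less inhibition, a higher number more inhibition at the concentration tested (going by the name of the read-out). Compound 1, `CC(=O)c1cc(CO)c(OCCCCCCC#N)cc1O`, gives 40% in this assay. Compound 2, `CCc1cc(C(C)=O)c(O)cc1OCCCC(C)(C)C(N)=O`, gives 92% in this assay and so stands highest of the two numbers; its nearest neighbour on this read-out is compound 1, whose number lies lower by more than the usual scatter. For the measured compounds named here, no pair of measured compounds differs in only one place, so the two values on their own are all that can be read. The next compound, compound 3, is `CCc1cc(C(C)=O)c(O)cc1OCCCCc1nnn[nH]1`. It differs from compound 2 in one place: (1H-tetrazol-5-yl)methyl in place of 1-carbamoyl-1-methylethyl on a saturated chain carbon, three bonds along the chain from an oxygen on an aromatic ring. Going by the values given here, with no single-point step among the measured compounds to lean on, any expectation for the step from compound 2 to compound 3 in this assay rests on the value of compound 2, 92%, and on the change itself. The step is expected to be small, downward if anything, a number 8 percentage points lower from compound 2 to compound 3 (within the scatter). Compound 3 is therefore expected to give about 84% in this assay, within a range from 60% to 98%.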

Compound 3, a percentage reported as inhibition, at one concentration (the size of the read-out at that concentration, not a potency): 49%
The estimate for compound 3 lay 35 percentage points above the measured number; measured number below the stated range.
By their numbers in this assay, from the lowest: compounds 1 and 3 (each within the scatter of the next); then compound 2.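

In this assay, for the compounds shown here, the exchange of 1-carbamoyl-1-methylethyl for (1H-tetrazol-5-yl)methyl on a saturated chain carbon, three bonds along the chain from an oxygen on an aromatic ring, gives the first single-point step of this set, a number 43 percentage points lower from compound 2 to compound 3 (beyond the scatter). The position is therefore not indifferent to what it carries: the two groups have the same count of heavy atoms and of hydrogen-bond donors and neither has a net charge, yet the numbers part by more than the scatter, so those counts alone do not set the read-out here. The data offer nothing that explains why this exchange lowers the inhibition at the concentration tested.

One step at one position cannot tell whether the change in the number follows from the five-membered aromatic ring that enters or from the carbamoyl that leaves. A carboxylic acid or an amine at the same place, or a longer chain carrying the same ring, would be needed to separate the two, and readings at a single concentration leave the potency of both compounds open.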